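Swapping methylsulfanyl for a selenium group on the shared core

The compounds below may be only part of what the source reports. "The series", "measured", "known", "first", "only" and "open" are said of these compounds alone.

Two compounds with the same central carbon, doubly bonded to nitrogen and flanked by two amide-type nitrogens, have been tested in a functional assay on K562 cells (Homo sapiens) for cytotoxicity, read by MTT assay, with a stated time of 72 h; a higher number here means a weaker inhibitor of growth, a lower number a stronger inhibitor of growth. Compound 1, `CS/C(=N\C(=O)c1sccc1Cl)NC(=O)c1sccc1Cl`, carries a methylsulfanyl group on that carbon and two chlorinated thiophene amides; in this assay compound 1 gives 78900 nM. Compound 2, `CS/C(=N\C(=O)c1ccno1)NC(=O)c1ccno1`, keeps the methylsulfanyl group but has isoxazole amides instead. For compound 2 only a limit is recorded in this assay, namely > 100000 nM, which is the edge of what this assay reports and not a number. The fact that the limit of > 100000 nM in this assay, at which 1 of the 2 values shown sits, means compound 2 stands as weaker than compound 1 can be said only loosely, since a limit cannot be compared exactly.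

Compound 3, `O=C(/N=C(/NC(=O)c1ccno1)[Se]Cc1ccccc1)c1ccno1`, is compound 2 with a group of 8 heavy atoms (7 carbon, 1 selenium; one six-membered aromatic ring of carbon only) in place of a group of 2 heavy atoms (1 carbon, 1 sulfur; no ring), on a carbon with a double bond to nitrogen. Among the measured compounds shown here, no measured step of this kind is available, so the expectation rests on general experience: a change of this size is expected to shift growth inhibition somewhat toward stronger, as a moderate step of an at least 2.0-fold lower number from compound 2 to compound 3 (0.30 log units; that floor lies within the scatter). Compound 3 is therefore estimated at 50000 nM, with a range from 15000 nM to 150000 nM.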

Compound 3, concentration for total growth inhibition: 57300 nM
Compound 3: middle estimate off by 1.1-fold (0.06 log units), on the low side; measured number inside the range.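

With the isoxazole amides held fixed, the place on a carbon with a double bond to nitrogen, whose other neighbours are amide-type nitrogens, accepts the much larger selenium group with its six-membered aromatic ring, and in this assay compound 3 gives a real number, 57300 nM. The change reads as an at least 1.7-fold lower number from compound 2 to compound 3 (0.24 log units; that floor lies within the scatter), so only a minimum size for the step is known, and that minimum does not by itself establish a real gain in growth inhibition. The step can be stated only as a minimum because compound 2 has no exact number, only a limit: the limit of > 100000 nM in this assay, at which 1 of the 3 values shown sits.

Selenium and the aromatic ring enter together in this one step, and the compounds shown do not separate them; a benzylsulfanyl group, with sulfur and the same ring, or a methylselanyl group, with selenium and no ring, would tell the two apart. Also open, as far as these compounds go, are what an amine on that carbon would do and whether the same selenium group would behave alike with the chlorinated thiophene amides of compound 1.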